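Methylsulfanyl in Place of Thiophen-2-yl at One Aromatic Carbon

The source may hold more compounds than are shown below. What is called first, only, known or untested is meant among the compounds shown, and "the series" means these compounds.

Measured so far in an ADME assay on PC-3 cells (Homo sapiens) for cytotoxicity, read by WST assay, tested at 100 uM; a higher number here means more inhibition at the concentration tested (going by the name of the read-out), a lower number less inhibition:
compound 1, `Cc1cccc(C(=O)N2CCCC(C(=O)Nc3ccc(Cl)cc3)C2)c1`, 0%;
compound 2, `CC(=O)Nc1cccc(C(=O)N2CCCC(C(=O)Nc3ccc(Cl)cc3)C2)c1`, 4%;
compound 3, `O=C(Nc1ccc(Cl)cc1)C1CCCN(C(=O)c2cccc(-c3cccs3)c2)C1`, 4%.

All three compounds share the same core and differ only in one group on an aromatic carbon. In this assay compound 3 stands level with compound 2 at the digits shown, the two of them together the highest of the three numbers, and a number 4 percentage points higher from compound 1 to compound 3 (within the scatter), so every value sits at the bottom of the scale and no compound can be set apart from another.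

The next compound, compound 4, is `CSc1cccc(C(=O)N2CCCC(C(=O)Nc3ccc(Cl)cc3)C2)c1`. It is reached from compound 3 by methylsulfanyl in place of thiophen-2-yl on an aromatic carbon.

Among the measured compounds shown here, two measured steps bear on this change, since both alter the same position on the ring: a number 4 percentage points higher from compound 1 to compound 3 (within the scatter) and no change at the digits printed from compound 2 to compound 3 (within the scatter). Neither the methyl, the acetamido nor the thiophen-2-yl group moved the read-out beyond the scatter, so a methylsulfanyl group at that carbon is not expected to do so either; the estimated step of a number 1 percentage points lower from compound 3 to compound 4 (within the scatter) is expected to lie within the scatter. For compound 4 the expected value in this assay is therefore 3%, estimated to fall between -7% and 13%.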

Compound 4, a percentage reported as inhibition, at one concentration (the size of the read-out at that concentration, not a potency): 0%
Estimate against measurement, compound 4: 3 percentage points above; measured number inside the range.
By their numbers in this assay, from the lowest: compounds 1, 4, 2 and 3 (each within the scatter of the next).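

In this assay, methylsulfanyl in place of thiophen-2-yl removes the five-membered aromatic ring from this aromatic carbon and gives a number 4 percentage points lower from compound 3 to compound 4 (within the scatter), so at this carbon the loss of that ring brings no step beyond the scatter. Set against the other two groups at the same carbon, methylsulfanyl gives a number 4 percentage points lower from compound 2 to compound 4 (within the scatter) and, from the methyl group, no change at the digits printed from compound 1 to compound 4 (within the scatter), so this fourth group also remains within the scatter of the other three and cannot be ranked against them. There is no supporting information that bears on these numbers.

The four compounds leave open whether any group at this carbon can lift the read-out clear of the bottom of the scale, for instance a primary amine, a carboxylic acid or a longer alkyl chain. They also leave open whether a change elsewhere on the shared core, such as a bromine in place of the chlorine, would separate compounds that this position has so far left indistinguishable.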